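Replacing the nitrophenyl amide with a methoxyphenyl amide

The source may hold more compounds than are shown below. What is called first, only, known or untested is meant among the compounds shown, and "the series" means these compounds.

Measured compounds:
compound 1, `CC(=O)Nc1ccc2nc(SCC(=O)NCc3ccccc3)sc2c1`, 9200 nM in a functional assay on HepG2 cells (Homo sapiens) for cytotoxicity, read by MTT assay, with a stated time of 48 h; a higher number here means a weaker inhibitor, a lower number a stronger inhibitor
compound 2, `O=C(CSc1nc2ccc(NC(=O)c3ccc([N+](=O)[O-])cc3)cc2s1)NCc1ccccc1`, > 100000 nM in this assay

Compound 2 stands only at a limit of this assay, not at a number; this is the limit described by the limit of > 100000 nM in this assay, at which 1 of the 2 values shown sits. Compound 3, `COc1ccccc1C(=O)Nc1ccc2nc(SCC(=O)NCc3ccccc3)sc2c1`, has not yet been measured. It differs from compound 2 in one place: 2-methoxyphenyl in place of 4-nitrophenyl on a carbonyl carbon.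

Within the data shown here, the only measured step, an at least 10-fold higher number from compound 1 to compound 2 (1.03 log units; beyond the scatter), swapped a methyl for a 4-nitrophenyl on that same carbonyl carbon and gave a weaker inhibitor. Among the measured compounds shown here, compound 3 keeps an aryl group there but exchanges the 4-nitrophenyl for a 2-methoxyphenyl, so no measured step covers this change directly. Compound 3 is therefore expected to remain weak, likely between the value of compound 1 and the limit, as the step of an at least 1.6-fold lower number from compound 2 to compound 3 (0.22 log units; that floor lies within the scatter) expresses. The estimate for compound 3 in this assay is 60000 nM, with a range from 15000 nM to 200000 nM.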

Compound 3, half-maximal inhibitory concentration: 8000 nM
For compound 3 the middle estimate is 7.5-fold (0.88 log units) above the measured one, outside the stated range (below it).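

Putting 2-methoxyphenyl in place of methyl on this carbonyl carbon gives a 1.2-fold lower number from compound 1 to compound 3 (0.06 log units; within the scatter), so in this assay the loss seen with compound 2 does not come with every aryl group placed here. Exchanging 4-nitrophenyl for 2-methoxyphenyl gives an at least 12-fold lower number from compound 2 to compound 3 (1.09 log units; beyond the scatter), which shows that the identity of the aryl group matters at this position, not merely its presence. Compound 2 is known only as a limit, so the size of this step is a floor: the limit of > 100000 nM in this assay, at which 1 of the 3 values shown sits.

The two aryl groups differ both in their substituent and in where it sits, and the compounds shown do not separate these two differences. A 4-methoxyphenyl, a 2-nitrophenyl or a plain phenyl group on the same carbonyl carbon would tell them apart.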